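The compounds below may be only part of what the source reports. "The series", "measured", "known", "first", "only" and "open" are said of these compounds alone.

Measured compounds:
Compound 1 `Cc1nn(CC(=O)N2CCN(c3sc(C(F)(F)F)nc3-c3nc4ccccc4[nH]3)C[C@H]2C)cc1CN(C)C` gives 330 nM in a functional assay on Venous blood for antagonist activity at C-X-C chemokine receptor type 3 (Homo sapiens), read by flow cytometry, with a stated time of 30 min, in the presence of a further agent that is not named here; on this read-out lower numbers stand for stronger inhibition and higher numbers for weaker inhibition.
Compound 2 `C[C@@H]1CN(c2sc(C(F)(F)F)nc2-c2nc3ccccc3[nH]2)CCN1C(=O)Cn1cc(Cl)cn1` gives 251 nM in this assay.
Compound 3 `Cc1nc(C)n(CC(=O)N2CCN(c3sc(C(F)(F)F)nc3-c3nc4ccccc4[nH]3)C[C@H]2C)n1` gives 237 nM in this assay.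

Compound 3 carries the lowest of the three numbers, but its separation from compound 2 a 1.1-fold lower number from compound 2 to compound 3 (0.02 log units; within the scatter) and from compound 1 a 1.4-fold lower number from compound 1 to compound 3 (0.14 log units; within the scatter) both lie within the scatter, so no order among the three can be claimed. Compound 4 `C[C@@H]1CN(c2sc(C(F)(F)F)nc2-c2nc3ccccc3[nH]2)CCN1C(=O)Cn1cnc2c1CCN(C)C2` is not yet measured. It differs from compound 3 in one place: a group of 10 heavy atoms (7 carbon, 3 nitrogen; one five-membered aromatic ring with 2 hetero atoms, one six-membered non-aromatic ring with 1 hetero atom) in place of a group of 7 heavy atoms (4 carbon, 3 nitrogen; one five-membered aromatic ring with 3 hetero atoms), on a saturated chain carbon bound to a carbonyl carbon. Among the compounds with values here, the steps that bear on this position are a 1.3-fold lower number from compound 1 to compound 2 (0.12 log units; within the scatter), a 1.4-fold lower number from compound 1 to compound 3 (0.14 log units; within the scatter) and a 1.1-fold lower number from compound 2 to compound 3 (0.02 log units; within the scatter), all of them within the scatter; three different groups on the saturated chain carbon bound to the carbonyl carbon gave essentially the same read-out in this assay. The group entering in compound 4 is larger than any of those, so the expectation rests on a wider extrapolation, but the evidence points to no step beyond the scatter, with a 1.2-fold higher number from compound 3 to compound 4 (0.09 log units; within the scatter) expected. Compound 4 is therefore estimated at 290 nM, within a range from 120 nM to 750 nM.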

Compound 4, half-maximal inhibitory concentration: 135 nM
Compound 4: the middle estimate sits 2.1-fold (0.33 log units) above what was measured, and the stated range covers the measured number.
By their numbers in this assay, from the lowest: compounds 4, 3, 2 and 1 (each within the scatter of the next, the first and the last beyond it).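

The saturated chain carbon bound to a carbonyl carbon also tolerates a larger group carrying a six-membered non-aromatic ring with 1 hetero atom: in this assay, a 1.8-fold lower number from compound 3 to compound 4 (0.24 log units; within the scatter) and a 1.9-fold lower number from compound 2 to compound 4 (0.27 log units; within the scatter) both stay within the scatter. Within the data shown here, the only step beyond the scatter at this position is a 2.4-fold lower number from compound 1 to compound 4 (0.39 log units; beyond the scatter), and it joins two groups of equal heavy-atom count, the entering one holding that six-membered non-aromatic ring and the leaving one lacking it. Nothing available here bears on why the read-out differs between these two groups.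

The compounds shown leave open how the read-out responds to a carboxylic acid or a primary amine in this place. Among these compounds, they also leave open whether a group with more heavy atoms than the one in compound 4 would keep the read-out in this range.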